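Swapping dimethylamino for ethyl: what to expect

This account rests on a few compounds, and the source may have more. Where it says the series, first, only, none or still open, it means among the compounds named here.

Compound 1 `O=C(/C=C/C1=Cc2ccccc2OC1)c1ccc(C(F)(F)F)cc1` and compound 2 `CN(C)c1ccc(C(=O)/C=C/C2=Cc3ccccc3OC2)cc1` share one core and differ only in a group on an aromatic carbon. In a functional assay on the whole organism for inhibition, with Mus musculus as the target, with a stated time of 1 h, at a dose of 30 mg/kg by the intraperitoneal route (on this read-out lower numbers stand for less inhibition and higher numbers for more inhibition at the one dose given (going by the name of the read-out)), compound 1 gives 75.5%, while compound 2 gives 57.3%; compound 2 thus stands lowest of the two numbers, and the step of a number 18.2 percentage points lower from compound 1 to compound 2 (beyond the scatter) is beyond the scatter. Compound 3 `CCc1ccc(C(=O)/C=C/C2=Cc3ccccc3OC2)cc1` carries the change (ethyl in place of dimethylamino on an aromatic carbon). Among the measured compounds shown here, no measured step involves ethyl, so only a number 18.2 percentage points lower from compound 1 to compound 2 (beyond the scatter) offers any guide, and it does not set the size of this step. Compound 3 is estimated at 65%, within 45% to 85%, an expected step of a number 7.7 percentage points higher from compound 2 to compound 3 (within the scatter) that could just exceed the scatter upward.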

Compound 3, a percentage reported as inhibition, in the whole organism at one dose (the size of the read-out at that dose, not a potency): 68.1%
For compound 3 the middle estimate is 3.1 percentage points below the measured one; the range from low to high includes it.
By their numbers in this assay, from the lowest: compound 2; then compounds 3 and 1 (each within the scatter of the next).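

At this position, on an aromatic carbon para to a large group, ethyl in place of dimethylamino gives a number 10.8 percentage points higher from compound 2 to compound 3 (beyond the scatter) in this assay, while ethyl in place of trifluoromethyl gives a number 7.4 percentage points lower from compound 1 to compound 3 (within the scatter), so compound 2 alone stands apart among the three compounds. The lower number therefore goes with dimethylamino here and is not shared by every replacement for trifluoromethyl. Nothing available explains this difference. Going by these compounds, whether an amine without methyl groups, a carboxylic acid or a longer chain at this position would group with compound 2 or with compound 1 and compound 3 remains open.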